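Trimming the Piperazine Substituent of a Dithiocarbamate Benzamide

The source may report more compounds than this note shows. Statements on the series, on what has been measured and on what is new or still open speak of the compounds shown alone.

Two dithiocarbamate benzamides have been measured in a functional assay on MGC-803 cells (Homo sapiens) for antiproliferative activity, read by CCK-8 assay, with a stated time of 72 h, tested at 2 uM; a lower number here means a weaker effect, a higher number a stronger effect of the compound at the concentration tested. Compound 1 `CN(C(=S)SCc1ccc(C(=O)Nc2ccccc2N)cc1)c1cccnc1` gives 46.1% there. Compound 2 `Cc1ccc(N2CCN(C(=S)SCc3ccc(C(=O)Nc4ccccc4N)cc3)CC2)cc1` gives 33.4%, the lowest of the two numbers, with compound 1 standing beyond the scatter above it. Compound 3 `CN1CCN(C(=S)SCc2ccc(C(=O)Nc3ccccc3N)cc2)CC1` is the next candidate, differing from compound 2 by methyl in place of 4-methylphenyl on an amine nitrogen in a ring. Within the data shown here, no measured pair follows this change, so the expectation rests only on these two values. The change is expected to move compound 3 little, with a number 1.6 percentage points higher from compound 2 to compound 3 (within the scatter) staying within the scatter. Compound 3 is thus estimated at 35% in this assay, within 15% to 55%.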

Compound 3, a percentage reported as inhibition, at one concentration (the size of the read-out at that concentration, not a potency): 29.6%
For compound 3 the middle estimate is 5.4 percentage points above the measured one; measured number inside the range.
By their numbers in this assay, from the lowest: compounds 3 and 2 (each within the scatter of the next); then compound 1.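

In this assay, replacing 4-methylphenyl with methyl on the amine nitrogen of the ring leaves the read-out within the scatter (a number 3.8 percentage points lower from compound 2 to compound 3 (within the scatter)), so among these two compounds the six-membered aromatic ring at this position makes no visible difference. Compound 3 does, however, stay clearly under compound 1 (a number 16.5 percentage points lower from compound 1 to compound 3 (beyond the scatter)), so 4-methylpiperazin-1-yl in place of methyl(pyridin-3-yl)amino on the thiocarbonyl carbon carries a step beyond the scatter. From the compounds shown here alone, whether an ethyl group, a 2-hydroxyethyl chain or a plain hydrogen on that nitrogen would shift the number remains open. Nothing available explains either step.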